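The source may hold more compounds than are shown below. What is called first, only, known or untested is meant among the compounds shown, and "the series" means these compounds.

Working notes on the series. Of the compounds shown here, three on the shared core have been measured: compound 1 `NC(=O)c1c(NC(=O)c2ccccc2Cl)sc2c1CCNC2`, compound 2 `NC(=O)c1c(NC(=O)c2ccccc2Cl)sc2c1CCN(Cc1ccccc1)C2` and compound 3 `NC(=O)c1c(NC(=O)c2ccccc2Cl)sc2c1CCN(Cc1ccc([N+](=O)[O-])cc1)C2`. In a functional assay on MKN-74 cells (Homo sapiens) for antiproliferative activity, with a stated time of 24 h (on this read-out higher numbers stand for weaker inhibition and lower numbers for stronger inhibition), compound 1 gives 28700 nM, compound 2 gives 14500 nM and compound 3 gives 31500 nM. Compound 2 has the lowest number of the three, but compound 1 sits within the scatter of it; only compound 3 stands beyond it. Changes on the amine nitrogen in the ring have so far moved the number little: a 2.0-fold lower number from compound 1 to compound 2 (0.30 log units; within the scatter) and a 1.1-fold higher number from compound 1 to compound 3 (0.04 log units; within the scatter), while a 2.2-fold higher number from compound 2 to compound 3 (0.34 log units; beyond the scatter).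

Compound 4 `COc1ccccc1NC(=S)N1CCc2c(sc(NC(=O)c3ccccc3Cl)c2C(N)=O)C1` is not yet measured. Against compound 2 the change is a group of 11 heavy atoms (8 carbon, 1 nitrogen, 1 oxygen, 1 sulfur; one six-membered aromatic ring of carbon only) in place of a group of 7 heavy atoms (7 carbon; one six-membered aromatic ring of carbon only), on an amine nitrogen in a ring; the entering group carries 1 double bond outside aromatic rings, 1 hydrogen-bond donor and 2 hydrogen-bond acceptors, where benzyl carries none. Among the measured compounds shown here, no measured step covers this exchange; the three steps above are the nearest guide and all are modest at most. The expectation is therefore a small step in this assay, in either direction and most likely within the scatter, so that a 1.4-fold higher number from compound 2 to compound 4 (0.14 log units; within the scatter) is the step estimated. For compound 4 the estimate is 20000 nM, with a range from 7000 nM to 60000 nM.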

Compound 4, half-maximal inhibitory concentration: 35200 nM
Estimate against measurement, compound 4: 1.8-fold (0.25 log units) below; the measured number falls inside the stated range.
By their numbers in this assay, from the lowest: compounds 2, 1, 3 and 4 (each within the scatter of the next, the first and the last beyond it).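

In this assay, the group of 11 heavy atoms on the amine nitrogen in the ring gives a 2.4-fold higher number from compound 2 to compound 4 (0.39 log units; beyond the scatter), a modest step and the largest seen so far at this position. The same group gives a 1.1-fold higher number from compound 3 to compound 4 (0.05 log units; within the scatter) and a 1.2-fold higher number from compound 1 to compound 4 (0.09 log units; within the scatter), both within the scatter, so compound 4 does not separate from compound 3 or from compound 1, and a group carrying a hydrogen-bond donor and a double bond outside aromatic rings reads the same here as 4-nitrobenzyl or a plain hydrogen atom. Among the compounds shown here, compound 2 remains the only compound with any step beyond the scatter, and that holds against compound 3 and compound 4 but not against compound 1; nothing on hand accounts for these differences.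

The compounds shown leave open whether any group on this nitrogen moves the number by more than a modest step, for example a phenethyl group, an acetyl group or a benzyl group bearing a carboxylic acid. They also leave open which part of the entering group goes with the step away from compound 2, as that group differs from benzyl in several features at once.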